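A few compounds are considered here, and "the series" means these few. Any claim that something is new, unique, unknown or untested is made for them only; others in the source may bear on it.

Three compounds share one core and differ only in the group on the amide-type nitrogen in the ring. Compound 1 `COc1ccc(-c2ccc3c(c2)C(=O)C(=O)N3)cc1` carries hydrogen there; in a functional assay on HepG2 cells (Homo sapiens) for antiproliferative activity, read by MTT assay, with a stated time of 48 h (a lower number here means a stronger inhibitor, a higher number a weaker inhibitor), compound 1 gives 960 nM. Compound 2 `COc1ccc(-c2ccc3c(c2)C(=O)C(=O)N3Cc2ccc(Cl)c(Cl)c2)cc1` carries a 3,4-dichlorobenzyl and gives 990 nM, a step of a 1.0-fold higher number from compound 1 to compound 2 (0.01 log units; within the scatter). Compound 3 `COc1ccc(-c2ccc3c(c2)C(=O)C(=O)N3Cc2cccc(Cl)c2)cc1` carries a 3-chlorobenzyl and gives 320 nM; it stands lowest of the three numbers, with steps of a 3.0-fold lower number from compound 1 to compound 3 (0.48 log units; beyond the scatter) and a 3.1-fold lower number from compound 2 to compound 3 (0.49 log units; beyond the scatter). Compound 4 `COc1ccc(-c2ccc3c(c2)C(=O)C(=O)N3Cc2ccc(C#N)cc2)cc1` has not been measured. The change is 4-cyanophenyl in place of 3-chlorophenyl on a saturated chain carbon bound to an amide-type nitrogen in a ring. Among the compounds with values here, no measured step exchanges a chloro for a nitrile, so none bears on it directly; the measured steps show only that 3-chlorobenzyl in place of hydrogen gave a 3.0-fold lower number from compound 1 to compound 3 (0.48 log units; beyond the scatter) and that hydrogen in place of chloro gave a 3.1-fold lower number from compound 2 to compound 3 (0.49 log units; beyond the scatter). The expected step is therefore uncertain, a 1.7-fold higher number from compound 3 to compound 4 (0.24 log units; within the scatter), with no direction beyond the scatter firmly expected. Compound 4 is estimated at 550 nM, between 200 nM and 1500 nM.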

Compound 4, half-maximal inhibitory concentration: 1000 nM
The estimate for compound 4 lay 1.8-fold (0.26 log units) below the measured number, within the range that was stated.
By their numbers in this assay, from the lowest: compound 3; then compounds 1, 2 and 4 (each within the scatter of the next).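

In this assay the swap of 3-chlorobenzyl for 4-cyanobenzyl loses the advantage of compound 3, giving a 3.1-fold higher number from compound 3 to compound 4 (0.49 log units; beyond the scatter) and showing that this position does not accept every substituted benzyl equally. Compound 4 also reads level with the 3,4-dichlorobenzyl compound, at a 1.0-fold higher number from compound 2 to compound 4 (0.00 log units; within the scatter) and with the compound carrying the amide hydrogen, at a 1.0-fold higher number from compound 1 to compound 4 (0.02 log units; within the scatter) so a substituted benzyl on this nitrogen does not by itself lower the number, and of the four compounds only compound 3 stands apart as the strongest. No measurement here explains why these benzyl groups differ.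

The change in compound 4 alters both the group and where it sits on the ring, so the two effects cannot be separated. Also open, on these data alone, is how an unsubstituted benzyl, a benzyl bearing an amine or a carboxylic acid, or a longer chain on this nitrogen would read.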